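A few compounds are considered here, and "the series" means these few. Any claim that something is new, unique, unknown or untested is made for them only; others in the source may bear on it.

Measured in a functional assay on MDA-MB-231 cells (Homo sapiens) for antiproliferative activity, read by sulforhodamine B assay, with a stated time of 72 h; on this read-out higher numbers stand for weaker inhibition and lower numbers for stronger inhibition:
- compound 1 `O=C(/C=C/c1csc2ccccc12)c1cc(F)ccc1O`: 8400 nM
- compound 2 `COc1ccc(O)c(C(=O)/C=C/c2csc3ccccc23)c1`: 760 nM
- compound 3 `CCOc1ccc(O)c(C(=O)/C=C/c2csc3ccccc23)c1`: 6700 nM

In this assay, compound 3 stands well above compound 2 and level with compound 1, since the step of a 1.3-fold lower number from compound 1 to compound 3 (0.10 log units; within the scatter) does not separate the two. The next compound, compound 4 `CC(C)Oc1ccc(O)c(C(=O)/C=C/c2csc3ccccc23)c1`, changes only the ethoxy group of compound 3, which becomes isopropoxy: methyl in place of hydrogen on a saturated chain carbon bound to an oxygen on an aromatic ring and a saturated chain carbon. For the measured compounds named here, the closest precedent is an 8.8-fold higher number from compound 2 to compound 3 (0.95 log units; beyond the scatter), which is the same kind of change, a methyl in place of hydrogen on a saturated chain carbon bound to an oxygen on an aromatic ring. That step went beyond the scatter. The other two steps, an 11-fold lower number from compound 1 to compound 2 (1.04 log units; beyond the scatter) and a 1.3-fold lower number from compound 1 to compound 3 (0.10 log units; within the scatter), replace fluoro with an alkoxy group, so they bear on this change only indirectly. They do show that the two alkoxy groups measured so far behave quite differently. With a single direct precedent, a modest further rise in the number is expected, probably smaller than the earlier one, and a change within the scatter remains possible. The expected step is a 1.3-fold higher number from compound 3 to compound 4 (0.13 log units; within the scatter). For compound 4 the estimated value is 9000 nM, with an expected range from 3000 nM to 27000 nM.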

Compound 4, half-maximal inhibitory concentration: 8500 nM
Compound 4: middle estimate off by 1.1-fold (0.02 log units), on the high side; the range from low to high includes it.
By their numbers in this assay, from the lowest: compound 2; then compounds 3, 1 and 4 (each within the scatter of the next).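

In this assay, the added methyl on this chain carbon turns ethoxy into isopropoxy and leaves the two compounds level (a 1.3-fold higher number from compound 3 to compound 4 (0.10 log units; within the scatter)), whereas the earlier methyl, which turned methoxy into ethoxy, produced a step beyond the scatter (an 8.8-fold higher number from compound 2 to compound 3 (0.95 log units; beyond the scatter)). The separation of methoxy from the larger alkoxy groups therefore holds for isopropoxy as well (an 11-fold higher number from compound 2 to compound 4 (1.05 log units; beyond the scatter)), so among the three alkoxy groups shown, only methoxy stands apart, while ethoxy and isopropoxy cannot be told apart. Isopropoxy is also level with fluoro at this aromatic carbon (a 1.0-fold higher number from compound 1 to compound 4 (0.01 log units; within the scatter)), which leaves compound 2 as the only one of the four whose number lies clearly lower, and compounds 1, 3 and 4 together as a level group.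

The compounds shown leave open whether a hydroxyl, an amine or a longer chain on this oxygen would stay level with compound 4 or move toward compound 2, and whether a plain hydroxyl in place of the whole alkoxy group would do either. Nothing measured here explains why methoxy stands apart from the other groups.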